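The compounds below may be only part of what the source reports. "The series", "measured", "known", "first", "only" and "open" are said of these compounds alone.

Going by the values given here, compound 1 `O=C(c1cccnc1)N1CCC(NS(=O)(=O)c2cc(S(=O)(=O)c3ccccc3)ccc2C(F)(F)F)CC1` is one of two compounds measured in an assay on U2OS cells for inhibition of secreted frizzled-related protein 1 (Homo sapiens), read by a luciferase reporter, with a stated time of 18 h (on this read-out lower numbers stand for an effect already at smaller amounts and higher numbers for an effect only at larger amounts of compound), where compound 1 gives 120 nM. Compound 2 `CC(C)(C)OC(=O)N1CC[C@H](C(=O)N2CCC(NS(=O)(=O)c3cc(S(=O)(=O)c4ccccc4)ccc3C(F)(F)F)CC2)C1` carries a 1-(tert-butoxycarbonyl)pyrrolidin-3-yl group in place of the pyridin-3-yl on the carbonyl carbon, and in this assay compound 2 gives 150 nM. The step of a 1.3-fold higher number from compound 1 to compound 2 (0.10 log units; within the scatter) puts compound 2 at the higher of the two numbers, though the two compounds cannot be told apart by this read-out.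

Compound 3 `O=C([C@@H]1CCNC1)N1CCC(NS(=O)(=O)c2cc(S(=O)(=O)c3ccccc3)ccc2C(F)(F)F)CC1` differs from compound 2 as follows: pyrrolidin-3-yl in place of 1-(tert-butoxycarbonyl)pyrrolidin-3-yl on a carbonyl carbon. Among the compounds with values here, neither measured step removes a tert-butoxycarbonyl group from the pyrrolidine, so the only step on hand, from compound 1 to compound 2, speaks to the same carbonyl position but not to this change. The step of no change at the digits printed from compound 2 to compound 3 (within the scatter) is therefore expected to stay within the scatter. Compound 3 is estimated at 150 nM, with a range from 50 nM to 450 nM.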

Compound 3, half-maximal effective concentration: 380 nM
Compound 3: the middle estimate sits 2.5-fold (0.40 log units) below what was measured, within the range that was stated.
By their numbers in this assay, from the lowest: compounds 1 and 2 (each within the scatter of the next); then compound 3.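

Taking away the tert-butoxycarbonyl group, so that pyrrolidin-3-yl sits on the carbonyl carbon, gives a 2.5-fold higher number from compound 2 to compound 3 (0.40 log units; beyond the scatter) in this assay, which shows that the number at this position can move with the group placed there, something the first pair could not show. Set against pyridin-3-yl, the same pyrrolidin-3-yl gives a 3.2-fold higher number from compound 1 to compound 3 (0.50 log units; beyond the scatter), so it stands apart from both earlier groups, although those two could not be told apart. Nothing available explains this shift.

A 1-acetylpyrrolidin-3-yl or 1-methylpyrrolidin-3-yl group on the same carbonyl carbon would show whether other groups on the pyrrolidine restore the lower number, or whether this is particular to tert-butoxycarbonyl. Going by these compounds, the effect of the opposite stereocentre in pyrrolidin-3-yl also remains open.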